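A few compounds are considered here, and "the series" means these few. Any claim that something is new, unique, unknown or untested is made for them only; others in the source may bear on it.

Compound 1 `COc1ccc(N(C)c2nc(Cl)nc3c2ncn3Cc2cc(OC)cc(OC)c2)cc1` in a functional assay on SH-SY5Y cells (Homo sapiens) for antiproliferative activity, read by MTT assay, with a stated time of 48 h (on this read-out lower numbers stand for stronger inhibition of growth and higher numbers for weaker inhibition of growth), gives > 100000 nM, which is a limit of the assay rather than a number (the limit of > 100000 nM in this assay, at which 1 of the 3 values shown sits). Compound 2 `COc1ccc(N(C)c2nc(Cl)nc3c2ncn3Cc2cc(OC)c(OC)c(OC)c2)cc1` differs from compound 1 by methoxy in place of hydrogen on an aromatic carbon; in this assay compound 2 gives 3000 nM, and the step is an at least 33-fold lower number from compound 1 to compound 2 (1.52 log units; beyond the scatter). Compound 3 `COc1cc(Cn2cnc3c(Cl)nc(Cl)nc32)cc(OC)c1` differs from compound 1 in its core by chloro in place of (4-methoxyphenyl)(methyl)amino on an aromatic carbon; in this assay compound 3 gives 1700 nM, a step of an at least 58-fold lower number from compound 1 to compound 3 (1.76 log units; beyond the scatter). The values of compound 2 and compound 3 lie within the scatter of each other.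

Compound 4 `COc1cc(Cn2cnc3c(Cl)nc(Cl)nc32)cc(OC)c1OC` is not yet measured. It relates to compound 3 by methoxy in place of hydrogen on an aromatic carbon, the same change as from compound 1 to compound 2, with the surroundings of the place described in the same words. That earlier step was large, though its size rests on the limit for compound 1 rather than on a number. On the core of compound 3 the step from compound 3 to compound 4 in this assay is expected to be a 4.3-fold lower number from compound 3 to compound 4 (0.63 log units; beyond the scatter). A smaller step than before is expected since compound 3 already stands at 1700 nM. Compound 4 is expected to give about 400 nM in this assay, with a likely range from 80 nM to 2000 nM.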

Compound 4, concentration for 50% growth inhibition: 9600 nM
Compound 4: middle estimate off by 24-fold (1.38 log units), on the low side; the measured number lies above the stated range.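

Methoxy in place of hydrogen on an aromatic carbon does not carry over between the two cores in this assay, where the new step is a 5.6-fold higher number from compound 3 to compound 4 (0.75 log units; beyond the scatter), opposite in direction to the earlier one: the same change on two cores in this assay, an at least 33-fold lower number (1.52 log units; beyond the scatter) from compound 1 to compound 2 and a 5.6-fold higher number (0.75 log units; beyond the scatter) from compound 3 to compound 4, at least 180-fold (2.27 log units) apart, beyond the scatter of two such steps

Chloro in place of (4-methoxyphenyl)(methyl)amino is likewise not transferable, since with the extra methoxy present it gives a 3.2-fold higher number from compound 2 to compound 4 (0.51 log units; beyond the scatter), again opposite in direction to the earlier step: the same change on two cores in this assay, an at least 58-fold lower number (1.76 log units; beyond the scatter) from compound 1 to compound 3 and a 3.2-fold higher number (0.51 log units; beyond the scatter) from compound 2 to compound 4, at least 180-fold (2.27 log units) apart, beyond the scatter of two such steps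

Compound 1 gives > 100000 nM, which is a limit of the assay and not a number; these four compounds establish that the two changes depend on each other, but not the exact size of that dependence or its cause.

Still open, from the compounds shown here alone, is whether hydroxy or ethoxy in place of the added methoxy would behave in the same way on each core. Going by these compounds, it is also open whether a smaller amine, such as dimethylamino, in place of (4-methoxyphenyl)(methyl)amino would give the same reversal.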